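Swapping a Dichlorobenzyl Group for Fluorobenzyl

A few compounds are considered here, and "the series" means these few. Any claim that something is new, unique, unknown or untested is made for them only; others in the source may bear on it.

Measured compounds:
- compound 1 `Nc1cc(N)c2nc(-c3ccccc3)c(NCc3ccc(Cl)c(Cl)c3)nc2c1` — 51300 nM
- compound 2 `COc1cc(CNc2nc3cc(N)cc(N)c3nc2-c2ccccc2)cc(OC)c1OC` — 20900 nM
- compound 3 `CCOC(=O)[C@H](CCC(=O)O)NC(=O)c1ccc(Oc2nc3cc(N)cc(N)c3nc2-c2ccccc2)cc1` — < 100000 nM

Of the compounds shown here, three sharing one core have been tested in a functional assay on SNB-19 cells (Homo sapiens) for inhibition, read by sulforhodamine B assay, with a stated time of 48 h; a lower number here means a stronger inhibitor of growth, a higher number a weaker inhibitor of growth. Compound 1 gives 51300 nM, the higher of the two numbers reported. Compound 2 gives 20900 nM, a lower number that lies beyond the scatter of the method. Compound 3 gives only a limit, < 100000 nM, so no number is known for it. That reading is described by the limit of < 100000 nM in this assay, at which 1 of the 3 values shown sits.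

Compound 4 `Nc1cc(N)c2nc(-c3ccccc3)c(NCc3ccc(F)cc3)nc2c1` has not yet been measured. It differs from compound 1 by 4-fluorophenyl in place of 3,4-dichlorophenyl on a saturated chain carbon bound to a nitrogen on an aromatic ring; seen one bond further out, this is 3,4-dichlorobenzyl giving way to 4-fluorobenzyl. For the measured compounds named here, no measured pair here shows this kind of exchange, and the two numbers available do not point in a direction for it. The step from compound 1 to compound 4 is therefore expected to be small, near the edge of the scatter, a 1.1-fold higher number from compound 1 to compound 4 (0.03 log units; within the scatter). Compound 4 is estimated at 55000 nM, with a range from 18000 nM to 160000 nM.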

Compound 4, concentration for total growth inhibition: 20000 nM
Compound 4: the middle estimate sits 2.8-fold (0.44 log units) above what was measured; measured number inside the range.
By their numbers in this assay, from the lowest: compounds 4 and 2 (each within the scatter of the next); then compound 1.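

In this assay, for the compounds shown here, the exchange gives a 2.6-fold lower number from compound 1 to compound 4 (0.41 log units; beyond the scatter) and this is the first step that can be read at this position. It shows that the group on a saturated chain carbon bound to a nitrogen on an aromatic ring is not indifferent to change: with the rest of the molecule held fixed, 4-fluorophenyl gives a modestly lower number than 3,4-dichlorophenyl. No measurement shown here accounts for this step.

The exchange alters both the kind of halogen and how many are present, so this single step cannot separate the two. As far as these compounds go, whether a 4-chlorophenyl group, a plain phenyl group or a longer chain in place of the benzyl group would lower the number further remains open.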